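Triazole Hydroxamates: From Compound 3 to Compound 4

The source may report more compounds than this note shows. Statements on the series, on what has been measured and on what is new or still open speak of the compounds shown alone.

Measured compounds in an assay on Sf9 cells for inhibition of protein deacetylase HDAC6 (Homo sapiens), read by fluorescence, with a stated time of 40 min, tested at 100 nM; a lower number here means less inhibition, a higher number more inhibition at the concentration tested (going by the name of the read-out):
Compound 1 `O=C(NO)c1ccc(NCc2nc(-c3cccc4cnccc34)nn2-c2ccccc2)cc1` gives 40.2%.
Compound 2 `O=C(NO)c1ccc(NCc2nc(-c3ccc(Cl)cc3)nn2-c2ccccc2)cc1` gives 67.2%.
Compound 3 `O=C(NO)c1ccc(NCc2nc(-c3ccc(Cl)c(Cl)c3)nn2-c2ccccc2)cc1` gives 34.5%.

Compound 3 stands lowest of the three numbers in this assay. Its nearest neighbour is compound 1, and that gap, a number 5.7 percentage points lower from compound 1 to compound 3 (within the scatter), is within the scatter, so no order between them can be claimed. Its furthest neighbour is compound 2, and that gap, a number 32.7 percentage points lower from compound 2 to compound 3 (beyond the scatter), is large and beyond the scatter. The step the other way, a number 27 percentage points higher from compound 1 to compound 2 (beyond the scatter), is modest.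

Compound 4 `O=C(NO)c1ccc(NCc2nc(-c3ccccc3Cl)nn2-c2ccccc2)cc1` carries the change (2-chlorophenyl in place of 3,4-dichlorophenyl on an aromatic carbon). The step from compound 2 to compound 3 bears on it most directly, since it shows what one chloro did on that ring; the step from compound 1 to compound 2 also bears on it, showing that a single chloro on the phenyl can sit with a higher number. Within the data shown here, no measured compound carries chloro in the 2-chlorophenyl arrangement, so the direction is uncertain. Compound 4 is expected to rise to 50%, between 25% and 75%, an expected step of a number 15.5 percentage points higher from compound 3 to compound 4 (beyond the scatter).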

Compound 4, a percentage reported as inhibition, at one concentration (the size of the read-out at that concentration, not a potency): 75%
Compound 4: the middle estimate sits 25 percentage points below what was measured, and the stated range covers the measured number.
By their numbers in this assay, from the lowest: compounds 3 and 1 (each within the scatter of the next); then compounds 2 and 4 (each within the scatter of the next).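

With the 2-chlorophenyl group at this position, this assay gives a large step (a number 40.5 percentage points higher from compound 3 to compound 4 (beyond the scatter)), and the isoquinolin-5-yl group of compound 1 also gives way to it with a large step (a number 34.8 percentage points higher from compound 1 to compound 4 (beyond the scatter)). Moving the single chloro from the 4-chlorophenyl to the 2-chlorophenyl arrangement leaves no readable difference (a number 7.8 percentage points higher from compound 2 to compound 4 (within the scatter)), so among these compounds both single-chloro groups stand clear of the 3,4-dichlorophenyl group, and a chloro in the 4-chlorophenyl arrangement does not on its own go with the low number of compound 3. No measured evidence accounts for this result.

Still open, as far as these compounds go, is whether a methoxy group or an amine on this phenyl ring would read with compound 4 or with compound 3. Also open, from the compounds shown here alone, is how an unsubstituted phenyl group at this position would compare with compound 4.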